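The source may report more compounds than this note shows. Statements on the series, on what has been measured and on what is new or still open speak of the compounds shown alone.

Of the compounds shown here, two have so far been measured in an assay on microsomes from liver (strain Wistar) for inhibition of acyl-CoA desaturase 1 (Rattus norvegicus), read by HPLC, with stated times of 1 h and 60 min; on this read-out higher numbers stand for weaker inhibition and lower numbers for stronger inhibition. Compound 1 `NC(=O)c1nc(N2CCC(Oc3ccccc3C(F)(F)F)CC2)no1` gives 1630 nM in this assay. Compound 2 `NS(=O)(=O)c1cnc(N2CCC(Oc3ccccc3C(F)(F)F)CC2)s1` gives 41 nM, the lower of the two numbers, and compound 1 stands well above it, beyond the scatter. Compound 3 `Cc1nnc(-c2cnc(N3CCC(Oc4ccccc4C(F)(F)F)CC3)s2)s1` has not yet been measured. It differs from compound 2 in a single place: 5-methyl-1,3,4-thiadiazol-2-yl in place of sulfamoyl on an aromatic carbon, so that a 5-methyl-1,3,4-thiadiazol-2-yl group takes the place of sulfamoyl on an aromatic carbon of a five-membered aromatic ring with 1 nitrogen and 1 sulfur, two ring bonds from the ring atom that bears a large group. Within the data shown here, no pair of measured compounds shows this exchange, so its size cannot be read from the numbers at hand; what is known is that the outgoing group has no ring while the incoming one is itself a five-membered aromatic ring with 3 hetero atoms. Compound 3 is expected to come out somewhat weaker than compound 2, a step of a 2.0-fold higher number from compound 2 to compound 3 (0.29 log units; within the scatter) that may still fall within the scatter. The estimate for compound 3 in this assay is 80 nM, in a range from 15 nM to 400 nM.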

Compound 3, half-maximal inhibitory concentration: 750 nM
For compound 3 the middle estimate is 9.4-fold (0.97 log units) below the measured one; the whole stated range lies below it.
By their numbers in this assay, from the lowest: compound 2; then compound 3; then compound 1.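

In this assay, putting 5-methyl-1,3,4-thiadiazol-2-yl in place of sulfamoyl on this aromatic carbon gives an 18-fold higher number from compound 2 to compound 3 (1.26 log units; beyond the scatter), so this place on the five-membered aromatic ring with 1 nitrogen and 1 sulfur does not treat the two groups alike. Among these compounds, the single exchange replaces a group with no ring and 1 hydrogen-bond donor by a five-membered aromatic ring with 3 hetero atoms and 0 hydrogen-bond donors, and this one pair cannot show which of these differences matters for the large step. Nothing at hand bears on why the step has this size.

The compounds shown leave open how a methylsulfonyl group, a carboxylic acid or an unsubstituted 1,3,4-thiadiazol-2-yl would stand at this position, and so whether the ring itself or the methyl on it goes with the higher number. Compound 1 differs from compound 2 and compound 3 in more than one place, so it does not help to settle what this position tolerates.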